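Swapping diethylamino for piperidin-1-yl on the ester chain

A few compounds are considered here, and "the series" means these few. Any claim that something is new, unique, unknown or untested is made for them only; others in the source may bear on it.

Compound 1 `CCN(CC)CC(=O)OC1CC2(N(C)C)CC(c3ccccc3)C1C(c1ccccc1)C2` gives 30100 nM
Compound 2 `CCN(CC)CC(=O)OC1CC2(N3CCCC3)CC(c3ccccc3)C1C(c1ccccc1)C2` gives 49000 nM
Compound 3 `CCN(CC)CC(=O)OC1CC2(N3CCCCC3)CC(c3ccccc3)C1C(c1ccccc1)C2` gives 23900 nM; 61300 nM (2 entries)

All of these numbers come from an ADME assay on L6 cells (Rattus norvegicus) for cytotoxicity (on this read-out higher numbers stand for weaker inhibition and lower numbers for stronger inhibition), and they sit close together. Going by the values given here, compound 1 lies within the scatter of compound 2, since the only measured step is a 1.6-fold higher number from compound 1 to compound 2 (0.21 log units; within the scatter) and that step is too small to count as a real change. Repeats can spread widely, as the several entries of compound 3 in this assay, 23900 nM; 61300 nM (2 entries) show, and those two entries fall on either side of the value for compound 1.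

Compound 4 `CN(C)C12CC(OC(=O)CN3CCCCC3)C(C(c3ccccc3)C1)C(c1ccccc1)C2` differs from compound 1 on a saturated chain carbon bound to a carbonyl carbon, where piperidin-1-yl replaces diethylamino (piperidin-1-yl in place of diethylamino on a saturated chain carbon bound to a carbonyl carbon). Among the compounds with values here, no measured step makes this exact change. The nearest comparison is the step to compound 2, which also brings in a ring amine, though on a saturated ring carbon and in place of dimethylamino. It stayed within the scatter, so it gives only weak guidance, but it offers no reason to expect a large shift in this assay here.

The expected outcome is a 1.1-fold higher number from compound 1 to compound 4 (0.03 log units; within the scatter) and no step beyond the scatter is anticipated. For compound 4 the estimated value is 32000 nM with an expected range from 13000 nM to 75000 nM in this read-out.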

Compound 4, half-maximal inhibitory concentration: 29300 nM
Compound 4: middle estimate off by 1.1-fold (0.04 log units), on the high side; low and high end bracket the measured number.
By their numbers in this assay, from the lowest: compounds 4, 1 and 2 (each within the scatter of the next).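

Going by these compounds alone, this is the first measured change on the ester chain rather than on the saturated ring carbon of the core. Piperidin-1-yl in place of diethylamino on a saturated chain carbon bound to a carbonyl carbon gives a 1.0-fold lower number from compound 1 to compound 4 (0.01 log units; within the scatter) and so shows no real shift in this assay. The amine at this place can therefore take up a six-membered non-aromatic ring without any change that this read-out can detect, and the step is far smaller than the spread between repeats of a single compound: the several entries of compound 3 in this assay, 23900 nM; 61300 nM (2 entries)

The compounds shown leave open whether other groups at this place, such as morpholin-4-yl, a primary amine or a carboxylic acid, or a longer chain between the carbonyl and the amine, would also stay within the scatter of compound 1. They also leave open whether any change on the ester chain can move the number beyond the scatter, since the only ester-chain swap shown here replaces one tertiary amine with another.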